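The source may hold more compounds than are shown below. What is called first, only, known or untested is meant among the compounds shown, and "the series" means these compounds.

Measured compounds in a functional assay on the whole organism (Tail, strain ICR) with Mus musculus as the target, in the tail flick test, with a stated time of 120 min, at a dose of 25 umol/kg by the oral route; on this read-out lower numbers stand for a weaker effect and higher numbers for a stronger effect at the one dose given:
compound 1, `O=C(CN(c1ncnc2c1ncn2C1CCCCO1)C1CC1)NCC(=O)OCc1ccccc1`, 17.2%
compound 2, `CC(C)(C)OC(=O)NCCCC[C@H](NC(=O)CN(c1ncnc2c1ncn2C1CCCCO1)C1CC1)C(=O)OCc1ccccc1`, 28.4%
compound 3, `CC(C)C[C@H](NC(=O)CN(c1ncnc2c1ncn2C1CCCCO1)C1CC1)C(=O)OCc1ccccc1`, 12.8%

Compound 3 stands lowest of the three numbers; its gap to compound 1 is within the scatter, so no order can be read between those two, while compound 2 stands above it beyond the scatter, a number 15.6 percentage points lower from compound 2 to compound 3 (beyond the scatter).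

Compound 4, `C[C@@H](O)[C@H](NC(=O)CN(c1ncnc2c1ncn2C1CCCCO1)C1CC1)C(=O)OCc1ccccc1`, is not yet measured. The change is 1-hydroxyethyl in place of isobutyl on a saturated chain carbon bound to an amide-type nitrogen and a carbonyl carbon. For the measured compounds named here, two measured steps concern the same carbon: a number 4.4 percentage points lower from compound 1 to compound 3 (within the scatter), within the scatter, and a number 15.6 percentage points lower from compound 2 to compound 3 (beyond the scatter), modest. Each change at this carbon therefore moved the read-out little or modestly. For compound 4 the expected step is a number 5.2 percentage points higher from compound 3 to compound 4 (within the scatter), small and upward, within or barely beyond the scatter. The expected value for compound 4 in this assay is 18%, between 8% and 30%.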

Compound 4, a percentage reported as activity, at one dose (the size of the read-out at that dose, not a potency): 10.9%
The estimate for compound 4 lay 7.1 percentage points above the measured number, within the range that was stated.
By their numbers in this assay, from the lowest: compounds 4, 3 and 1 (each within the scatter of the next); then compound 2.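

In this assay, 1-hydroxyethyl in place of isobutyl on this carbon leaves the read-out unresolved (a number 1.9 percentage points lower from compound 3 to compound 4 (within the scatter)), and so does 1-hydroxyethyl in place of hydrogen (a number 6.3 percentage points lower from compound 1 to compound 4 (within the scatter)). Against 4-((tert-butoxycarbonyl)amino)butyl the gap is clear (a number 17.5 percentage points lower from compound 2 to compound 4 (beyond the scatter)), so among the four groups at this carbon only that chain stands apart. No available evidence accounts for these results.

Open, on these data alone, is whether a free amine on the butyl chain would keep the higher number of compound 2. Also open, as far as these compounds go, is how a carboxylic acid on this carbon would read out.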